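From furan-2-yl to 4-(trifluoromethyl)phenyl on the saturated ring carbon

The source may hold more compounds than are shown below. What is called first, only, known or untested is meant among the compounds shown, and "the series" means these compounds.

Measured so far:
- Compound 1 `c1ccc(COc2ccc(C3CC(c4ccc5c(c4)OCCO5)=NN3c3ccccc3)cc2)cc1`: 1130 nM
- Compound 2 `c1ccc(N2N=C(c3ccc4c(c3)OCCO4)CC2c2ccco2)cc1`: > 100000 nM

All values come from a functional assay on WM 266-4 cells (Homo sapiens) for antiproliferative activity, read by MTT assay, with a stated time of 24 h; on this read-out higher numbers stand for weaker inhibition of growth and lower numbers for stronger inhibition of growth. In this series compound 2 gives > 100000 nM, which is a limit of the assay and not a number. Going by the values given here, that leaves compound 2 with no exact position, and the only information on it is the limit of > 100000 nM in this assay, at which 1 of the 2 values shown sits. Compound 1 gives a true number at 1130 nM.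

The next compound is compound 3 `FC(F)(F)c1ccc(C2CC(c3ccc4c(c3)OCCO4)=NN2c2ccccc2)cc1`, which differs from compound 2 by 4-(trifluoromethyl)phenyl in place of furan-2-yl on a saturated ring carbon. In words, this is 4-(trifluoromethyl)phenyl in place of furan-2-yl on a saturated ring carbon.

Among the compounds with values here, no step between measured compounds is available to size this change, so the expectation is loose. A large move towards stronger inhibition of growth is expected, resting on the number reached by compound 1 at 1130 nM. The expected step is an at least 20-fold lower number from compound 2 to compound 3 (1.30 log units; beyond the scatter). For compound 3 the estimated value is 5000 nM, with an expected range of 900 nM to 30000 nM.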

Compound 3, concentration for 50% growth inhibition: > 100000 nM
Compound 3: a limit, no number (the forecaster's own chance of this, stated with the estimate: 10%); at least 20-fold (1.30 log units) between middle value and limit.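

In this assay the change from furan-2-yl to 4-(trifluoromethyl)phenyl on the saturated ring carbon cannot be read, because compound 2 and compound 3 both stand at a limit of the assay and not at a number: the limit of > 100000 nM in this assay, at which 2 of the 3 values shown sit.

The comparison that can be read is on the aromatic carbon of the group carried by that saturated ring carbon, where trifluoromethyl in place of benzyloxy gives an at least 88-fold higher number from compound 1 to compound 3 (1.94 log units; beyond the scatter). This is new information on the position: a six-membered aromatic ring on the saturated ring carbon does not by itself give a measurable value, and within this pair the measurable value goes with benzyloxy, the group present in compound 1 and absent from compound 3.

Going by these compounds, it remains open whether a shorter ether such as methoxy, an amine or a hydroxyl group on the same aromatic carbon would keep a measurable value, or whether the full benzyloxy group is needed. On these data alone, how furan-2-yl and 4-(trifluoromethyl)phenyl rank against each other also stays open, since neither compound 2 nor compound 3 has an exact position.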